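From Nitro to Methoxy: Tolerance of Compound 3 Estimated

This account rests on a few compounds, and the source may have more. Where it says the series, first, only, none or still open, it means among the compounds named here.

Compound 1, `S=C(Nc1ccccc1)OCCc1ccccc1`: in an ADME assay on MT4 cells (Homo sapiens) for cytotoxicity, read by MTT assay (a higher number here means that more compound is tolerated, a lower number that less compound is tolerated), compound 1 gives 100000 nM.
Compound 2, `O=[N+]([O-])c1ccc(NC(=S)OCCc2ccccc2)cc1`: in this assay compound 2 gives only the limit > 100000 nM.

Compound 2 thus stands at the upper edge of what this assay reports, namely (the limit of > 100000 nM in this assay, at which 1 of the 2 values shown sits), so no number is known for it, only that it sits at or beyond that edge. For the measured compounds named here, the one measured step, a number no lower from compound 1 to compound 2 (the limit leaves the size open), therefore has no readable size.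

Compound 3, `COc1ccc(NC(=S)OCCc2ccccc2)cc1`, remains to be measured in this assay. It differs from compound 2 in one place: methoxy in place of nitro on an aromatic carbon. Going by the values given here, no measured step covers a methoxy group, and the single step that touches the same position, a number no lower from compound 1 to compound 2 (the limit leaves the size open), is open in size. The expectation for compound 3 therefore rests on the two values alone. Compound 1, which carries neither group, gives 100000 nM. Compound 2 gives only the limit > 100000 nM. Compound 3 is expected to fall close to both, with a step of a number no higher from compound 2 to compound 3 (the limit leaves the size open) that is not expected to exceed the scatter. The estimate for compound 3 in this assay is 100000 nM, within a range from 40000 nM to 200000 nM.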

Compound 3, half-maximal cytotoxic concentration: 36000 nM
Estimate against measurement, compound 3: 2.8-fold (0.44 log units) above; measured number below the stated range.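

Methoxy gives the first readable step at this position on the aromatic carbon para to a large group: in this assay, methoxy in place of hydrogen brings a 2.8-fold lower number from compound 1 to compound 3 (0.44 log units; beyond the scatter), which lies beyond the scatter. Methoxy in place of nitro at the same carbon brings an at least 2.7-fold lower number from compound 2 to compound 3 (0.44 log units; beyond the scatter), so the tolerated concentration does depend on which group sits here, and the earlier pair alone could not show this. The size of that second step remains only a bound, and the step between the two earlier compounds cannot be read, because compound 2 carries only a limit: the limit of > 100000 nM in this assay, at which 1 of the 3 values shown sits.

The compounds shown leave open whether an amine, a chlorine atom or a longer alkoxy chain at this carbon would lower the number as methoxy does or leave it where compound 1 stands. They also leave open whether methoxy would bring a step of similar size on any core other than the shared one.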